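The compounds below may be only part of what the source reports. "The series", "measured", "known", "first", "only" and "open" are said of these compounds alone.

Compound 1 `C=C1CC[C@@H]2[C@](C)(COC(=O)c3cccnc3)[C@H](OC(=O)c3cccnc3)CC[C@@]2(C)[C@@H]1/C=C/C1=C/C(=C\c2ccccc2)OC1=O` and compound 2 `C=C1CC[C@@H]2[C@](C)(COC(=O)c3cccnc3)[C@H](OC(=O)c3cccnc3)CC[C@@]2(C)[C@@H]1/C=C/C1=C/C(=C\c2ccc(N(C)C)cc2)OC1=O` share one core and differ at a single aromatic carbon. In an assay on isolated protein for inhibition of Maltase-glucoamylase (Homo sapiens), tested at 100 uM (a higher number here means more inhibition at the concentration tested (going by the name of the read-out), a lower number less inhibition), compound 1 gives 100%, whereas compound 2 gives 74.8%, the lower of the two numbers, and the step of a number 25.2 percentage points lower from compound 1 to compound 2 (beyond the scatter) lies beyond the scatter. Compound 3 `C=C1CC[C@@H]2[C@](C)(COC(=O)c3cccnc3)[C@H](OC(=O)c3cccnc3)CC[C@@]2(C)[C@@H]1/C=C/C1=C/C(=C\c2ccc(OC)cc2)OC1=O` brings the change (methoxy in place of dimethylamino on an aromatic carbon). For the measured compounds named here, only that one step bears on it, and it ran downward when dimethylamino replaced hydrogen. Since methoxy is neither the hydrogen of compound 1 nor the dimethylamino of compound 2, a modest upward step a number 10.2 percentage points higher from compound 2 to compound 3 (beyond the scatter) is expected in this assay. Compound 3 is estimated at 85%, within 65% to 100%.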

Compound 3, a percentage reported as inhibition, at one concentration (the size of the read-out at that concentration, not a potency): 100%
Estimate against measurement, compound 3: 15 percentage points below; measured number inside the range.
By their numbers in this assay, from the lowest: compound 2; then compounds 1 and 3 (each within the scatter of the next).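

In this assay the lower number seen with dimethylamino does not hold for every group on this aromatic carbon: the change to methoxy gives a number 25.2 percentage points higher from compound 2 to compound 3 (beyond the scatter) while, set against hydrogen, methoxy gives no change at the digits printed from compound 1 to compound 3 (within the scatter) at this place. Among these three compounds, then, a group para to a large group does not by itself lower the number, and only dimethylamino stands apart. Nothing available here accounts for the difference between the two groups. Going by these compounds, whether a chlorine, a carboxylic acid or a primary amine on this carbon would follow methoxy or dimethylamino stays open.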